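The source may hold more compounds than are shown below. What is called first, only, known or untested is meant among the compounds shown, and "the series" means these compounds.

Of the compounds shown here, three of a shared core have been measured in an assay on isolated protein for binding affinity to 5-hydroxytryptamine receptor 1B (Homo sapiens); on this read-out lower numbers stand for stronger inhibition and higher numbers for weaker inhibition. Compound 1 `COc1cc2c(cc1N1C[C@@H](C)N(C)[C@@H](C)C1)N(C(=O)Nc1cccc(Cl)c1Cl)CC2` gives 7.94 nM. Compound 2 `COc1cc2c(cc1N1C[C@@H](C)N(C)[C@@H](C)C1)N(C(=O)c1ccc(-c3ccc(-c4noc(C)n4)cc3C)cc1)CC2` gives 5.01 nM, the lowest of the three numbers, though compound 1 and compound 3 both lie within the usual scatter of it. Compound 3 `COc1cc2c(cc1N1C[C@@H](C)N[C@@H](C)C1)N(C(=O)c1ccc(-c3cc(C)ncc3C)cc1)CC2` gives 7.94 nM. Compound 4 `COc1cc2c(cc1N1C[C@@H](C)N[C@@H](C)C1)N(C(=O)c1ccc(-c3ccc(-c4noc(C)n4)cc3C)cc1)CC2` has not yet been measured; it differs from compound 2 in one place: hydrogen in place of methyl on an amine nitrogen in a ring. Compound 3 also carries the unsubstituted ring nitrogen, and its value stays close to those of the other two, so no step beyond the scatter is expected; the estimated step of a 1.2-fold higher number from compound 2 to compound 4 (0.08 log units; within the scatter) is small. Compound 4 is expected to give about 6 nM, somewhere between 2 nM and 18 nM.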

Compound 4, inhibition constant: 3.16 nM
Compound 4: middle estimate off by 1.9-fold (0.28 log units), on the high side; measured number inside the range.
By their numbers in this assay, from the lowest: compounds 4, 2, 1 and 3 (each within the scatter of the next, the first and the last beyond it).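

In this assay, putting hydrogen in place of methyl on the amine nitrogen gives a 1.6-fold lower number from compound 2 to compound 4 (0.20 log units; within the scatter). For the compounds shown here, this is the first pair differing in only this one place, and it shows that 3,4,5-trimethylpiperazin-1-yl and 3,5-dimethylpiperazin-1-yl cannot be told apart on this read-out when the rest of the molecule is held constant. Nothing available explains this result. From the compounds shown here alone, whether larger groups on this nitrogen, such as ethyl or acetyl, fit the same picture remains open. So does whether the same swap gives a similar result on the other compounds.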